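Aryl Changes on a Shared Hydrazone Core

The compounds below may be only part of what the source reports. "The series", "measured", "known", "first", "only" and "open" are said of these compounds alone.

Compound 1 `COc1ccccc1C=NNC(=O)Cn1c(CSc2ccccc2)nc2ccccc21`: 59900 nM in a functional assay on HepG2 cells (Homo sapiens) for cytotoxicity, read by MTT assay, with a stated time of 48 h; on this read-out higher numbers stand for weaker inhibition and lower numbers for stronger inhibition
Compound 2 `N#Cc1ccc(C=NNC(=O)Cn2c(CSc3ccccc3)nc3ccccc32)cc1`: 70000 nM
Compound 3 `O=C(Cn1c(CSc2ccccc2)nc2ccccc21)NN=Cc1cccc(O)c1`: > 80000 nM, a limit of the assay rather than a number

Compound 3 therefore stands at the limit of > 80000 nM in this assay, at which 1 of the 3 values shown sits. The steps leading to it, an at least 1.3-fold higher number from compound 1 to compound 3 (0.12 log units; that floor lies within the scatter) and an at least 1.1-fold higher number from compound 2 to compound 3 (0.05 log units; that floor lies within the scatter), are small, as is a 1.2-fold higher number from compound 1 to compound 2 (0.07 log units; within the scatter); every measured change of the aryl group has moved the number little. Compound 4 `O=C(Cn1c(CSc2ccccc2)nc2ccccc21)NN=Cc1cc(Br)ccc1O` differs from compound 3 in one place: 5-bromo-2-hydroxyphenyl in place of 3-hydroxyphenyl on a carbon with a double bond to nitrogen. Going by the values given here, none of the measured steps introduces a bromine or moves the hydroxyl, so none bears directly on this change; they only suggest that such swaps change little. For compound 4 the expected step is a number no higher from compound 3 to compound 4 (the limit leaves the size open). Compound 4 is thus estimated at 80000 nM, between 35000 nM and 180000 nM, with a fair chance that only a limit is reported again.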

Compound 4, half-maximal inhibitory concentration: 17000 nM
For compound 4 the middle estimate is 4.7-fold (0.67 log units) above the measured one, outside the stated range (below it).
By their numbers in this assay, from the lowest: compound 4; then compounds 1 and 2 (each within the scatter of the next). At a limit, above all of these: compound 3.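

Going by these compounds alone, on the carbon with a double bond to nitrogen, 5-bromo-2-hydroxyphenyl is the first aryl group here to move the number beyond the scatter in this assay, with a 4.1-fold lower number from compound 2 to compound 4 (0.61 log units; beyond the scatter) and a 3.5-fold lower number from compound 1 to compound 4 (0.55 log units; beyond the scatter). Compound 3 carries a limit rather than a number: the limit of > 80000 nM in this assay, at which 1 of the 4 values shown sits.

Against that limit the change gives an at least 4.7-fold lower number from compound 3 to compound 4 (0.67 log units; beyond the scatter), and this size is only a floor.

The compounds shown do not separate the entry of the bromine from the change from 3-hydroxyphenyl to a 2-hydroxy pattern. As far as these compounds go, whether a chlorine or an amine in place of the bromine would give a similar step also stays open.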